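The compounds below may be only part of what the source reports. "The series", "measured", "known", "first", "only" and "open" are said of these compounds alone.

Working notes on the series, read in an ADME assay on J774 cells (Mus musculus) for cytotoxicity; on this read-out lower numbers stand for an effect already at smaller amounts and higher numbers for an effect only at larger amounts of compound. For the measured compounds named here, only two compounds have numbers so far. Compound 1 `CCCCCC/C=C\Cc1c(C)[nH]c2ccccc2c1=O` gives 48500 nM. Compound 2 `CCc1c(C)[nH]c2cc(OC)c(F)cc2c1=O` gives 9400 nM, the lower of the two numbers and beyond the scatter from the other, so compound 2 shows its effect at the smaller amount. These two compounds differ in more than one place, so the pair does not isolate any single change.

Compound 3 `CCc1c(C)[nH]c2cc(OC)c(Br)cc2c1=O` has not yet been measured. Relative to compound 2, the change is bromo in place of fluoro on an aromatic carbon, ortho to a methoxy group. Going by the values given here, no measured pair shows what a change at this place does, so the expectation rests only on compound 2 at 9400 nM and on the change itself. A small shift towards a lower number is expected, of a size that may well stay within the scatter. The estimated step is a 1.4-fold lower number from compound 2 to compound 3 (0.16 log units; within the scatter). For compound 3 the expected value is 6500 nM, with an estimated range of 2500 nM to 17000 nM.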

Compound 3, half-maximal effective concentration in the J774 assay: > 33900 nM
Compound 3 ended at the assay's limit (the forecaster's own chance of this, stated with the estimate: 5%); middle value at least 5.2-fold (0.71 log units) away from the limit.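

The aromatic carbon ortho to a methoxy group proves sensitive to the identity of the halogen: in the J774 assay, bromo in place of fluoro gives an at least 3.6-fold higher number from compound 2 to compound 3 (0.55 log units; beyond the scatter), so compound 3 shows its effect only at larger amounts of compound. In a physicochemical assay for lipophilicity, at pH 7.4 (a higher number here means a more lipophilic compound, a lower number a more polar compound), compound 2 gives 1.2 and compound 3 gives 1.7. In this single pair, the compound with the higher distribution coefficient is also the one with the higher cytotoxicity number, so a rise in lipophilicity does not bring the effect to smaller amounts here: the measured distribution coefficient of compound 2, 1.2, and of compound 3, 1.7, a number 0.50 log units higher (beyond the scatter). The reading for compound 3 in the J774 assay is a limit and not a number: the limit of > 33900 nM in the J774 assay, at which 1 of the 3 values shown sits.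

On these data alone, with only fluoro and bromo seen at this place, and the reading for compound 3 being a limit, the full size of the step stays unknown, and one pair cannot separate the identity of the halogen from the accompanying shift in distribution coefficient. A chloro group, a nitrile or an amine on the same aromatic carbon would show whether the cytotoxicity number follows the distribution coefficient or depends on the particular group.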